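The compounds below may be only part of what the source reports. "The series", "measured", "known", "first", "only" and "open" are said of these compounds alone.

Values in a functional assay on SK-MEL-28 cells (Homo sapiens) for inhibition (on this read-out lower numbers stand for stronger inhibition and higher numbers for weaker inhibition), so far:
- compound 1 (`CC(=O)Oc1ccc(/C=C/c2ccc3ccccc3c2)cc1`) gives > 5000 nM as a limit
- compound 2 (`COc1ccc(/C=C/c2ccc3ccccc3c2)cc1`) gives > 5000 nM as a limit
- compound 3 (`CN(C)c1ccc(/C=C/c2ccc3ccccc3c2)cc1`) gives 3660 nM as a number

Compound 2 stands at the limit of > 5000 nM in this assay, at which 2 of the 3 values shown sit, and so has no number of its own. Compound 4 (`CCN(CC)c1cc(/C=C/c2ccc3ccccc3c2)ccc1OC`) differs from it by one change (diethylamino in place of hydrogen on an aromatic carbon), diethylamino in place of hydrogen on an aromatic carbon, ortho to a methoxy group.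

Among the compounds with values here, two measured steps bear on this: first an at least 1.3-fold lower number from compound 2 to compound 3 (0.13 log units; that floor lies within the scatter) and second an at least 1.3-fold lower number from compound 1 to compound 3 (0.13 log units; that floor lies within the scatter) and neither floor goes beyond the scatter. Compound 3 carries dimethylamino in place of the methoxy group, whereas compound 4 keeps that group and gains diethylamino, so both steps are only a loose guide. A small move toward lower numbers is expected, not clearly beyond the scatter. The expected step is an at least 1.2-fold lower number from compound 2 to compound 4 (0.09 log units; that floor lies within the scatter) and it remains an estimate. In this assay the estimate for compound 4 is 4000 nM with an expected range of 1500 nM to 12000 nM and a reading at the limit remains about as likely as a number.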

Compound 4, half-maximal inhibitory concentration: > 5000 nM
Compound 4: only a limit was reported; the forecaster's own chance of this, stated with the estimate: 50%; middle value at least 1.2-fold (0.09 log units) away from the limit.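

In this assay, within the data shown here, compound 2 and compound 4 both sit at the same limit, so no step between them can be read: the limit of > 5000 nM in this assay, at which 3 of the 4 values shown sit. The compounds shown leave open whether diethylamino in place of hydrogen on an aromatic carbon shifts inhibition at all.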